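The source may report more compounds than this note shows. Statements on the series, on what has been measured and on what is new or still open speak of the compounds shown alone.

Compound 1 `Brc1ccc2[nH]cc(C(c3ccccc3)c3c[nH]c4ccc(Br)cc34)c2c1`: 900 nM
Compound 2 `Oc1ccc(C(c2c[nH]c3ccc(Br)cc23)c2c[nH]c3ccc(Br)cc23)cc1`: 4000 nM
Compound 3 `Oc1cccc(C(c2c[nH]c3ccc(Br)cc23)c2c[nH]c3ccc(Br)cc23)c1`: 3900 nM

In a functional assay on HeLa cells (Homo sapiens) for inhibition, read by MTT assay, with a stated time of 48 h (on this read-out higher numbers stand for weaker inhibition and lower numbers for stronger inhibition), compound 1 stands at the lowest of the three numbers, with compound 3 nearest and compound 2 furthest, both beyond the scatter. Compound 4 `Brc1ccc2[nH]cc(C(c3ccc4ccccc4c3)c3c[nH]c4ccc(Br)cc34)c2c1` has not yet been measured. It differs from compound 1 in one place: naphthalen-2-yl in place of phenyl on a saturated chain carbon bound to two aromatic carbons. The measured steps all concern a hydroxy group: a 4.4-fold higher number from compound 1 to compound 2 (0.65 log units; beyond the scatter) and a 4.3-fold higher number from compound 1 to compound 3 (0.64 log units; beyond the scatter), while a 1.0-fold lower number from compound 2 to compound 3 (0.01 log units; within the scatter). For the measured compounds named here, none of them exchanges one aromatic ring for a larger one without adding a hydroxy, so no measured step bears directly on the change to compound 4. Compound 4 is therefore expected to stay close to compound 1, with an estimated step of no change at the digits printed from compound 1 to compound 4 (within the scatter) that need not go beyond the scatter. The estimate for compound 4 is 900 nM, ranging from 300 nM to 2700 nM.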

Compound 4, half-maximal inhibitory concentration: 4300 nM
The estimate for compound 4 lay 4.8-fold (0.68 log units) below the measured number, outside the stated range (above it).
By their numbers in this assay, from the lowest: compound 1; then compounds 3, 2 and 4 (each within the scatter of the next).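

In this assay this position on the saturated chain carbon bound to two aromatic carbons proves sensitive to a change without any hydroxy, with a 4.8-fold higher number from compound 1 to compound 4 (0.68 log units; beyond the scatter) for naphthalen-2-yl in place of phenyl. The readings of a 1.1-fold higher number from compound 3 to compound 4 (0.04 log units; within the scatter) and a 1.1-fold higher number from compound 2 to compound 4 (0.03 log units; within the scatter) leave these three compounds level, so among the compounds shown, phenyl alone keeps the lowest number. Nothing available explains this result.

As far as these compounds go, whether an amine, a carboxylic acid or a longer chain in place of phenyl would stay near compound 1 or join compound 4 remains open.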